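The source may hold more compounds than are shown below. What is called first, only, known or untested is meant among the compounds shown, and "the series" means these compounds.

Among the compounds with values here, compound 3, `COc1cc(/C=C/C(=O)/C=C/c2cccc3ccccc23)ccc1OCc1cn(CCOc2cc(=O)oc3ccccc23)nn1`, is the second highest of the three numbers so far in a functional assay on THP-1 cells (Homo sapiens) for inhibition, read by sulforhodamine B assay, with a stated time of 48 h, tested at 50 uM; a lower number here means less inhibition of growth, a higher number more inhibition of growth at the concentration tested: compound 2, `COc1ccc(/C=C/C(=O)/C=C/c2ccc(OCc3cn(CCOc4cc(=O)oc5ccccc45)nn3)c(OC)c2)cc1OC`, gives 90%, and compound 1, `COc1ccccc1/C=C/C(=O)/C=C/c1ccc(OCc2cn(CCOc3cc(=O)oc4ccccc34)nn2)c(OC)c1`, gives 75%, while compound 3 gives 89%. The gap to compound 2 is within the scatter, a number 1 percentage points lower from compound 2 to compound 3 (within the scatter); the gap to compound 1 is beyond it, a number 14 percentage points higher from compound 1 to compound 3 (beyond the scatter).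

Compound 4, `COc1cccc(/C=C/C(=O)/C=C/c2ccc(OCc3cn(CCOc4cc(=O)oc5ccccc45)nn3)c(OC)c2)c1`, differs from compound 3 by 3-methoxyphenyl in place of naphthalen-1-yl on a double-bonded chain carbon bound to a double-bonded chain carbon.

Within the data shown here, the steps that bear on this change are those that put a methoxy-bearing phenyl against naphthalen-1-yl at this place: a number 14 percentage points higher from compound 1 to compound 3 (beyond the scatter) and a number 1 percentage points lower from compound 2 to compound 3 (within the scatter). Going back from naphthalen-1-yl to a methoxyphenyl therefore cost nothing against the dimethoxy case and lost modestly against the 2-methoxyphenyl case. Among the measured compounds shown here, no measured compound carries 3-methoxyphenyl, so the outcome in this assay is bracketed by those two. A small decrease is expected, a number 8 percentage points lower from compound 3 to compound 4 (within the scatter), likely within the scatter. Compound 4 is estimated at 81%, expected to lie between 66% and 92%.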

Compound 4, percent growth inhibition at one concentration: 77%
Estimate against measurement, compound 4: 4 percentage points above, within the range that was stated.
By their numbers in this assay, from the lowest: compounds 1 and 4 (each within the scatter of the next); then compounds 3 and 2 (each within the scatter of the next).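

In this assay, the replacement of naphthalen-1-yl gives (a number 12 percentage points lower from compound 3 to compound 4 (beyond the scatter)), while moving the single methoxy from 2-methoxyphenyl to 3-methoxyphenyl gives (a number 2 percentage points higher from compound 1 to compound 4 (within the scatter)), so at this place on a double-bonded chain carbon the two monomethoxy compounds cannot be told apart and both sit under naphthalen-1-yl. The dimethoxy comparison, new to the series, isolates one methoxy: hydrogen in its place on an aromatic carbon gives (a number 13 percentage points lower from compound 2 to compound 4 (beyond the scatter)), so among the methoxyphenyl compounds only 3,4-dimethoxyphenyl reaches the level of naphthalen-1-yl. No measured evidence on the origin of these steps is at hand.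

Open, on these data alone, is whether a phenyl bearing a dimethylamino group or a carboxylic acid would hold that level at this place. The compounds shown also leave open how the order holds at other concentrations, since each reading comes from a single tested concentration.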